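Replacing the pyridin-4-yl arm with 3-hydroxyphenyl

A few compounds are considered here, and "the series" means these few. Any claim that something is new, unique, unknown or untested is made for them only; others in the source may bear on it.

Compound 1 `Oc1cccc(-c2cc(-c3ccccc3)cc(-c3cccs3)n2)c1`: 51.2%
Compound 2 `Oc1cccc(-c2cc(-c3ccccc3)cc(-c3ccsc3)n2)c1`: 75.8%
Compound 3 `Oc1cccc(-c2cc(-c3ccccc3)cc(-c3ccncc3)n2)c1`: 70.4%

These three compounds share one core and differ only in a single aromatic arm, all tested in an assay on isolated protein for inhibition of DNA topoisomerase 1 (Homo sapiens), with a stated time of 30 min, tested at 100 uM; a higher number here means a stronger effect of the compound at the concentration tested, a lower number a weaker effect. Compound 3 stands second of the three: its number lies within the scatter of compound 2, as a number 5.4 percentage points lower from compound 2 to compound 3 (within the scatter) shows, and beyond the scatter above compound 1, as a number 19.2 percentage points higher from compound 1 to compound 3 (beyond the scatter) shows. Compound 4 `Oc1cccc(-c2cc(-c3ccccc3)cc(-c3cccc(O)c3)n2)c1` is not yet measured; it differs from compound 3 by 3-hydroxyphenyl in place of pyridin-4-yl on an aromatic carbon. For the measured compounds named here, no measured step places a 3-hydroxyphenyl group there. The closest guide is the exchange of one aromatic arm for another in a number 5.4 percentage points lower from compound 2 to compound 3 (within the scatter), which stayed within the scatter, whereas a number 24.6 percentage points higher from compound 1 to compound 2 (beyond the scatter) rose modestly. Compound 4 is therefore expected to differ little from compound 3, a number 0.4 percentage points lower from compound 3 to compound 4 (within the scatter), with an estimated 70% and a range from 55% to 85%.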

Compound 4, a percentage reported as inhibition, at one concentration (the size of the read-out at that concentration, not a potency): 67.2%
The estimate for compound 4 lay 2.8 percentage points above the measured number; the measured number falls inside the stated range.
By their numbers in this assay, from the lowest: compound 1; then compounds 4, 3 and 2 (each within the scatter of the next).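

The position tolerates a switch from a ring with a nitrogen to a carbon-only ring carrying a hydrogen-bond donor in this assay, with a number 3.2 percentage points lower from compound 3 to compound 4 (within the scatter) and a number 8.6 percentage points lower from compound 2 to compound 4 (within the scatter). Thiophen-2-yl remains the one arm set apart, with a number 16 percentage points higher from compound 1 to compound 4 (beyond the scatter). Nothing available here explains these differences.

Whether the hydroxyl itself contributes remains open, since an unsubstituted phenyl at this position is not among the compounds shown. So does the outcome of placing an amine or a carboxylic acid on this ring instead.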